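The source may hold more compounds than are shown below. What is called first, only, known or untested is meant among the compounds shown, and "the series" means these compounds.

Measured compounds:
- compound 1, `O=C(CCCCc1ccccc1)c1nc2ncccc2o1`: 0.3 nM in an assay on isolated protein for inhibition of Fatty-acid amide hydrolase 1 (Homo sapiens); on this read-out lower numbers stand for stronger inhibition and higher numbers for weaker inhibition
- compound 2, `CCCCCCCC/C=C\CCCCCCC(=O)c1nnn(C)n1`: 65 nM in this assay
- compound 3, `CCCCCC(=O)C(F)(F)F`: 28900 nM in this assay

Compound 2 sits second highest of the three numbers. The nearest number belongs to compound 1, whose value lies far below that of compound 2, beyond the scatter; the furthest belongs to compound 3, whose value lies far above, also beyond the scatter. No pair of these compounds differs in a single place, so no measured step can be read off directly.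

Compound 4, `CCCCCCCC/C=C\CCCCCCC(=O)c1nc2ncccc2o1`, keeps the unsaturated chain of compound 2 and changes only the ring attached to the carbonyl: a group of 9 heavy atoms (6 carbon, 2 nitrogen, 1 oxygen; one five-membered aromatic ring with 2 hetero atoms, one six-membered aromatic ring with 1 hetero atom) in place of a group of 6 heavy atoms (2 carbon, 4 nitrogen; one five-membered aromatic ring with 4 hetero atoms), on a carbonyl carbon. Within the data shown here, the group that enters is the one present in compound 1, and compound 1 gives 0.3 nM in this assay. The chain of compound 4 differs from that of compound 1, so the two are not a matched pair, and the effect of the chain is not isolated by any measured step.

The expectation is a large step to a lower number, well beyond the scatter, estimated as a 65-fold lower number from compound 2 to compound 4 (1.81 log units; beyond the scatter). Compound 4 is expected to give about 1 nM, with a range from 0.2 nM to 6 nM.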

Compound 4, inhibition constant: 2.3 nM
Compound 4: the middle estimate sits 2.3-fold (0.36 log units) below what was measured; low and high end bracket the measured number.
By their numbers in this assay, from the lowest: compound 1; then compound 4; then compound 2; then compound 3.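

In this assay, the series now has its first readable step, a 28-fold lower number from compound 2 to compound 4 (1.45 log units; beyond the scatter). Among these compounds, with the unsaturated chain held fixed, the exchange of 2-methyl-2H-tetrazol-5-yl for the ring group of compound 1 on the carbonyl carbon moves the number well beyond the scatter, showing that this position responds strongly to this change, which the earlier compounds, none differing in one place, could not show. No measurement available here bears on the cause of this step.

The other steps among these compounds cannot be read, so the contribution of the chain, which separates compound 4 from compound 1, remains unresolved, as does any contribution of the trifluoromethyl group of compound 3. Also open, from the compounds shown here alone, are whether an amine or a carboxylic acid added to the ring group of compound 4 would keep its number in this assay, and whether a longer chain would carry the same step from the tetrazole to the ring group.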